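Pyrazole urea inhibitors: methyl removal in compound 3

The source may hold more compounds than are shown below. What is called first, only, known or untested is meant among the compounds shown, and "the series" means these compounds.

Compound 1 `N#Cc1cnn(C(=O)NCc2ccc(OCc3ccccc3)cc2)c1` gives 60 nM in an assay on membranes from brain for binding affinity to Fatty-acid amide hydrolase 1 (Mus musculus), read by fluorescence, with stated times of 1 h and 30 min (on this read-out higher numbers stand for weaker inhibition and lower numbers for stronger inhibition), and compound 2 `CN(CCN(C)C(=O)n1cccn1)Cc1ccc(OCc2ccccc2)cc1` gives 510 nM. Compound 3 `Cc1cnn(C(=O)N(C)CCN(C)Cc2cccc(OCc3ccccc3)c2)c1` gives 9000 nM, the highest number of the three, set apart from both others beyond the scatter. Compound 4 `CN(CCN(C)C(=O)n1cccn1)Cc1cccc(OCc2ccccc2)c1` is not yet measured; it differs from compound 3 by hydrogen in place of methyl on an aromatic carbon. For the measured compounds named here, no single-change step covers this in this assay; compound 2 lacks the methyl but differs in more than one place from compound 3, so the value of compound 2, 510 nM, is only a hint. A moderate drop toward lower numbers is expected, a 3.0-fold lower number from compound 3 to compound 4 (0.48 log units; beyond the scatter), without reaching compound 2. Compound 4 is estimated at 3000 nM, range 700 nM to 12000 nM.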

Compound 4, half-maximal inhibitory concentration: 3000 nM
Compound 4: the middle estimate sits on the measured number at the digits printed, within the range that was stated.
By their numbers in this assay, from the lowest: compound 1; then compound 2; then compound 4; then compound 3.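

Going from 4-methyl-1H-pyrazol-1-yl to 1H-pyrazol-1-yl gives the first single-change reading at this position in this assay: a 3.0-fold lower number from compound 3 to compound 4 (0.48 log units; beyond the scatter). Loss of the methyl alone leaves a gap, since compound 4 gives 3000 nM and compound 2 gives 510 nM. No measurement at hand bears on the origin of this step. Open, as far as these compounds go, is how an amine or a carboxylic acid on this aromatic carbon would read, and whether a methyl there has a similar effect on the core of compound 2.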